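Swapping a chlorophenyl for a methoxy-bearing chain at the hydroxyl carbon

The compounds below may be only part of what the source reports. "The series", "measured", "known", "first", "only" and "open" are said of these compounds alone.

Of the compounds shown here, two built on one shared core have been tested in an ADME assay on liver for metabolic stability, with Liver microsome (Homo sapiens) as the target, read by LC-MS, using microsomes; a higher number here means faster removal of the compound, a lower number slower removal. Compound 1 `O=C(NCc1cc(Cl)ccc1-n1cnnn1)[C@@H]1C[C@@H]2C[C@@H]2N1C(=O)[C@H](O)c1cccc(Cl)c1` sits at a limit of this assay rather than at a number, since its value in this assay is > 500 mL.min-1.g-1. Among the compounds with values here, the reading says only that compound 1 stands at the limit of > 500 mL.min-1.g-1 in this assay, at which 1 of the 2 values shown sits. Compound 2 `O=C(NCc1cc(Cl)ccc1-n1cnnn1)[C@@H]1C[C@H]2C[C@H]2N1C(=O)[C@H](O)c1cccc(F)c1`, whose value in this assay is 32 mL.min-1.g-1, gives a definite number. Within the data shown here, no single-change step between these two has been worked out, so their two values are simply recorded side by side.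

Compound 3 `COC(C)(C)[C@@H](O)C(=O)N1[C@H](C(=O)NCc2cc(Cl)ccc2-n2cnnn2)C[C@@H]2C[C@@H]21` has not yet been measured. It differs from compound 1 by 1-methoxy-1-methylethyl in place of 3-chlorophenyl on a saturated chain carbon bound to a carbonyl carbon and an oxygen on a saturated carbon. Among the measured compounds shown here, with no measured step to lean on, the size of the step from compound 1 to compound 3 is a guess, but with compound 1 at a limit a move to a lower reading is the more likely outcome, beyond the scatter. Compound 3 is expected to give 150 mL.min-1.g-1 in this assay, within a range from 50 mL.min-1.g-1 to 500 mL.min-1.g-1, which would mean an estimated step of an at least 3.3-fold lower number from compound 1 to compound 3 (0.52 log units; beyond the scatter).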

Compound 3, intrinsic clearance in microsomes: 40 mL.min-1.g-1
Estimate against measurement, compound 3: 3.8-fold (0.57 log units) above, outside the stated range (below it).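

This is the first single-change step among these compounds, and it shows that the group on the saturated chain carbon bound to a carbonyl carbon and an oxygen on a saturated carbon has a strong bearing on the reading in this assay: putting 1-methoxy-1-methylethyl in place of 3-chlorophenyl gives an at least 12-fold lower number from compound 1 to compound 3 (1.09 log units; beyond the scatter). The change also shows that this position can do without the aromatic ring and still give a definite number in this read-out, although the step alters the ring, the chlorine and the oxygen all at once. Going by these compounds, the full size of the step stays unknown because compound 1 stands at a limit of the assay: the limit of > 500 mL.min-1.g-1 in this assay, at which 1 of the 3 values shown sits.

On these data alone, with only one replacement to read at this position, it remains open whether the lower number goes with losing the ring, losing the chlorine or gaining the methoxy oxygen. A tert-butyl group, which has the same branched carbon without the oxygen, and a cyclohexyl ring, which is a saturated ring of carbon only, would help to separate these three changes.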